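Benzyl ether change from compound 2 to compound 3

The source may report more compounds than this note shows. Statements on the series, on what has been measured and on what is new or still open speak of the compounds shown alone.

Compound 1 `COc1cccc(C(=O)Oc2ccc3c(=O)c(-c4cc(OC)c(OC)cc4OC)coc3c2)c1`: > 10000 nM (a limit)
Compound 2 `COc1cc(OC)c(-c2coc3cc(OCc4ccc(Br)cc4)ccc3c2=O)cc1OC`: 1980 nM

Going by the values given here, in a functional assay on HCT-116 cells (Homo sapiens) for antiproliferative activity, read by MTT assay, with a stated time of 24 h (on this read-out lower numbers stand for stronger inhibition and higher numbers for weaker inhibition), compound 2 gives 1980 nM, the only true number so far. Compound 1 gives only a limit, > 10000 nM. Compound 3 `COc1cc(OC)c(-c2coc3cc(OCc4ccccc4C)ccc3c2=O)cc1OC` has 2-methylphenyl in place of 4-bromophenyl on a saturated chain carbon bound to an oxygen on an aromatic ring.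

Among the compounds with values here, the only measured step bearing on this is an at least 5.0-fold lower number from compound 1 to compound 2 (0.70 log units; beyond the scatter). It exchanged (3-methoxyphenyl)carbonyl for 4-bromobenzyl on the same oxygen, and its size is bounded by the limit of > 10000 nM in this assay, at which 1 of the 2 values shown sits. The benzyl unit of compound 2 stays in compound 3, so a smaller change is expected in this assay, with a slightly higher number somewhat more likely. The expected step is a 1.3-fold higher number from compound 2 to compound 3 (0.10 log units; within the scatter). Compound 3 is estimated at 2500 nM, with an expected range of 800 nM to 8000 nM.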

Compound 3, half-maximal inhibitory concentration: 2900 nM
The estimate for compound 3 lay 1.2-fold (0.06 log units) below the measured number; measured number inside the range.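

In this assay, 2-methylphenyl in place of 4-bromophenyl on a saturated chain carbon bound to an oxygen on an aromatic ring gives a 1.5-fold higher number from compound 2 to compound 3 (0.17 log units; within the scatter), so this exchange does not separate the two benzyl groups. The gain over (3-methoxyphenyl)carbonyl on the same oxygen now holds for a second benzyl group, with an at least 3.4-fold lower number from compound 1 to compound 3 (0.53 log units; beyond the scatter). The size of that step stays bounded, as compound 1 gives only a limit: the limit of > 10000 nM in this assay, at which 1 of the 3 values shown sits.

Going from 4-bromobenzyl to 2-methylbenzyl alters both the substituent and its place on the ring, so the two contributions remain unseparated. Also open, on these data alone, is whether a benzyl group carrying an amine or a carboxylic acid, or a plain longer alkyl chain on this oxygen, would move the number beyond the scatter.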